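The source may hold more compounds than are shown below. What is called first, only, known or untested is meant among the compounds shown, and "the series" means these compounds.

Measured compounds in a functional assay on HeLa cells (Homo sapiens) for antiproliferative activity, read by MTT assay, with a stated time of 3 days; on this read-out lower numbers stand for stronger inhibition and higher numbers for weaker inhibition:
Compound 1 `Cc1ccc(C#Cc2cn(C/C=C\CN3C(=O)c4ccccc4C3=O)c(=O)[nH]c2=O)cc1` gives > 100000 nM, which is a limit of the assay and not a number.
Compound 2 `CCCCC#Cc1cn(C/C=C/CN2C(=O)c3ccccc3C2=O)c(=O)[nH]c1=O` gives 89000 nM.

Compound 1 therefore stands at the limit of the assay, where one of the two values sits (the limit of > 100000 nM in this assay, at which 1 of the 2 values shown sits); no number is known for it, only that it lies at that boundary. Compound 2 gives a number, but a weak one. The unmeasured compound 3 `CCCCc1ccc(C#Cc2cn(C/C=C\CN3C(=O)c4ccccc4C3=O)c(=O)[nH]c2=O)cc1` differs from compound 1 by propyl in place of hydrogen on a saturated chain carbon bound to an aromatic carbon. Within the data shown here, no measured step between two compounds is available, so the effect of this change is not known from the data. The expected step of a number no higher from compound 1 to compound 3 (the limit leaves the size open) is none beyond the scatter. Compound 3 is estimated at 100000 nM, with a range from 40000 nM to 300000 nM, and it is expected that the assay may again report only a limit.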

Compound 3, half-maximal inhibitory concentration: 85000 nM
Compound 3: the middle estimate sits 1.2-fold (0.07 log units) above what was measured; low and high end bracket the measured number.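

In this assay, propyl in place of hydrogen on a saturated chain carbon bound to an aromatic carbon gives an at least 1.1-fold lower number from compound 1 to compound 3 (0.07 log units; that floor lies within the scatter), so this position tolerates the change from 4-methylphenyl to 4-butylphenyl, and the assay now returns a number for this series. Compound 1 still holds only a limit, > 100000 nM, which is not a number, so the step has a floor but no known size: the limit of > 100000 nM in this assay, at which 1 of the 3 values shown sits. Compound 3, at 85000 nM, remains weak, and nothing shown so far establishes a change at this position that lies beyond the scatter.

As far as these compounds go, whether an amine, a carboxylic acid or a longer chain at this place would give a clearly stronger number stays open. Also open, from the compounds shown here alone, is whether the same change would read alike on the other double-bond arrangement seen in compound 2.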